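Replacing One Sulfonyl Group of Compound 1

The source may hold more compounds than are shown below. What is called first, only, known or untested is meant among the compounds shown, and "the series" means these compounds.

- compound 1 `COc1ccc(S(=O)(=O)Nc2ccc(-c3nc4cc(NS(=O)(=O)c5ccc(OC)cc5)ccc4o3)cc2)cc1`: 57000 nM
- compound 2 `O=S(=O)(Nc1ccc(-c2nc3cc(NS(=O)(=O)c4ccc(Br)cc4)ccc3o2)cc1)c1ccc(Br)cc1`: 18000 nM

In an ADME assay on FHC cells (Homo sapiens) for cytotoxicity, read by resazurin assay, with a stated time of 48 h (a higher number here means that more compound is tolerated, a lower number that less compound is tolerated), compound 1 gives 57000 nM, the higher of the two measured numbers. Compound 2 gives 18000 nM, and the gap between the two lies beyond the usual scatter.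

Among the measured compounds shown here, the next compound to be tested is compound 3 `COc1ccc(S(=O)(=O)Nc2ccc3oc(-c4ccc(NC(=O)C5CCN(C(C)=O)CC5)cc4)nc3c2)cc1`, which has no measurement yet. It departs from compound 1 at one place, on a nitrogen on an aromatic ring, where (1-acetylpiperidin-4-yl)carbonyl stands in place of (4-methoxyphenyl)sulfonyl: (1-acetylpiperidin-4-yl)carbonyl in place of (4-methoxyphenyl)sulfonyl on a nitrogen on an aromatic ring.

For the measured compounds named here, no measured pair of compounds shows a change of this kind. The expectation therefore starts from compound 1 at 57000 nM and carries real uncertainty in both directions. The expected step in this assay is a 1.1-fold higher number from compound 1 to compound 3 (0.02 log units; within the scatter), with no change beyond the scatter anticipated in either direction. For compound 3, the estimated value is 60000 nM, with an expected range of 20000 nM to 170000 nM.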

Compound 3, half-maximal cytotoxic concentration: > 100000 nM
Compound 3: only a limit was reported; the forecaster's own chance of this, stated with the estimate: 35%; at least 1.6-fold (0.22 log units) between middle value and limit.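

In this assay, the position on a nitrogen on an aromatic ring takes a carbonyl-linked group with a non-aromatic ring in place of a sulfonyl-linked aromatic one with no drop in the number: (1-acetylpiperidin-4-yl)carbonyl in place of (4-methoxyphenyl)sulfonyl gives an at least 1.7-fold higher number from compound 1 to compound 3 (0.24 log units; that floor lies within the scatter). Compound 1 and compound 2 both carry a sulfonyl group at each of the two nitrogens, so neither showed what happens when one of these groups is changed alone, while the other (4-methoxyphenyl)sulfonyl group stays in place. The size of the rise cannot be read, because only its floor is known and the value for compound 3 is a limit, not a number: the limit of > 100000 nM in this assay, at which 1 of the 3 values shown sits.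

The compounds shown leave open which part of the entering group carries this result, since the acetyl, the piperidine ring and the carbonyl link all enter together; a free piperidine amine or a plain benzoyl group at the same place would separate them. They also leave open whether the same replacement at the other sulfonyl-bearing nitrogen of the shared core would give the same outcome.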